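Stilbenes at the assay limit: demethylation of compound 3

This account rests on a few compounds, and the source may have more. Where it says the series, first, only, none or still open, it means among the compounds named here.

Measured so far:
compound 1, `COc1cc(/C=C/c2ccccc2)cc(OC)c1`, gives > 10000 nM in an assay on HEK293 cells for antagonist activity at transient receptor potential cation channel subfamily V member 1 (Homo sapiens), read by calcium flux (on this read-out lower numbers stand for stronger inhibition and higher numbers for weaker inhibition), which is a limit of the assay and not a number.
compound 2, `CC(=O)Oc1ccc(/C=C/c2ccccc2)cc1`, gives > 10000 nM in this assay, again a limit.
compound 3, `COc1cccc(/C=C/c2ccc(O)cc2)c1`, gives > 10000 nM in this assay, also a limit.

All three measured compounds share a stilbene-type core and differ only in the substitution on the two aromatic rings. None of them gives a number in this assay; every value shown is a limit. Compound 3 therefore stands nowhere in particular: its result is the same limit as the other two, as summarised by the limit of > 10000 nM in this assay, at which 3 of the 3 values shown sit, and no ordering among compounds 1, 2 and 3 can be drawn from these data.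

Compound 4, `Oc1ccc(/C=C/c2cccc(O)c2)cc1`, has not yet been measured in this assay. It differs from compound 3 by hydrogen in place of methyl on an oxygen on an aromatic ring.

Going by the values given here, no step between measured compounds is available, so the size of the change from a methoxy to a hydroxy group on this core cannot be read from the series. Given that compound 3 sits at the limit > 10000 nM, the step that the limit leaves unreadable from compound 3 to compound 4 is expected to be small and most likely to leave compound 4 at the same limit. Compound 4 is accordingly estimated at 15000 nM, within a range from 4000 nM to 50000 nM.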

Compound 4, half-maximal inhibitory concentration: > 10000 nM
Compound 4 was reported as a limit (the forecaster's own chance of this, stated with the estimate: 70%); the middle value is on the limit's open side.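

The step from methoxy to hydroxy between compound 3 and compound 4 cannot be read, as both results are limits of the assay and not numbers: the limit of > 10000 nM in this assay, at which 4 of the 4 values shown sit.

The compounds shown leave open whether any substitution on the shared core gives a number in this assay and how far each compound lies beyond the limit.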